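Cytotoxicity of a Bromophenyl Amide Analogue

A few compounds are considered here, and "the series" means these few. Any claim that something is new, unique, unknown or untested is made for them only; others in the source may bear on it.

Measured compounds in an ADME assay on Vero cells (Chlorocebus sabaeus) for cytotoxicity, read by resazurin assay, with a stated time of 3 days; on this read-out lower numbers stand for stronger inhibition and higher numbers for weaker inhibition:
Compound 1 `CCN(CC)c1cc2[nH]c(C3CCCCC3)nc2cc1NC(=O)OCCOCCOC` gives > 100 ug/mL, a limit of the assay rather than a number.
Compound 2 `CCN(CC)c1cc2[nH]c(C3CCCCC3)nc2cc1NC(=O)c1cnccn1` gives > 100 ug/mL, likewise a limit.
Compound 3 `CCCCNC(=O)Nc1cc2nc(C3CCCCC3)[nH]c2cc1N(CC)CC` gives > 100 ug/mL, again a limit.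

Going by the values given here, compound 3 thus sits at the limit of > 100 ug/mL in this assay, at which 3 of the 3 values shown sit, and every other measured compound sits there too, so no compound can be ordered against another in this assay. Compound 4 `CCN(CC)c1cc2[nH]c(C3CCCCC3)nc2cc1NC(=O)c1cccc(Br)c1` differs from compound 3 in one place: 3-bromophenyl in place of butylamino on a carbonyl carbon. The measured steps that bear on this change are a step that the two limits leave unreadable from compound 1 to compound 2, a step that the two limits leave unreadable from compound 1 to compound 3 and a step that the two limits leave unreadable from compound 2 to compound 3; each joins two limits, so no size can be read from them. Exchanging the group on the carbonyl carbon among 2-(2-methoxyethoxy)ethoxy, pyrazin-2-yl and butylamino left every value at the limit, and the change to 3-bromophenyl is expected to behave the same way. The step of a number no higher from compound 3 to compound 4 (the limit leaves the size open) is therefore expected to stay within the scatter, with the result most likely reported once more as a limit. Compound 4 is estimated to give 100 ug/mL in this assay, within a range from 40 ug/mL to 250 ug/mL, and a limit rather than a number is the more probable outcome.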

Compound 4, half-maximal inhibitory concentration: > 100 ug/mL
Compound 4: only a limit was reported; the forecaster's own chance of this, stated with the estimate: 70%; the middle value sits exactly at the limit.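

In this assay compound 4 gives > 100 ug/mL, a limit of the assay and not a number. Compound 4 cannot be ordered against compound 1, compound 2 or compound 3, so no new step can be read: the limit of > 100 ug/mL in this assay, at which 4 of the 4 values shown sit. The compounds shown leave open which group on the carbonyl carbon, if any, would give a number instead of a limit.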